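The compounds below may be only part of what the source reports. "The series", "measured", "known", "first", "only" and "open" are said of these compounds alone.

Working notes on the series.

Compound 1 `O=C(NNc1ccnc2cc(Cl)ccc12)c1ccccc1/N=C/c1ccccc1Cl` stands lowest of the three measured compounds in a physicochemical assay for lipophilicity, measured as octanol-water partition (on this read-out lower numbers stand for lower lipophilicity and higher numbers for higher lipophilicity), where compound 1 gives 5.5. Compound 2 `O=C(NNc1ccnc2cc(Cl)ccc12)c1ccccc1/N=C/c1ccc(Cl)cc1` gives 5.62 in this assay, and compound 3 `O=C(NNc1ccnc2cc(Cl)ccc12)c1ccccc1/N=C/c1ccc(Cl)cc1Cl` gives 6.22. The steps among them are a number 0.12 log units higher from compound 1 to compound 2 (within the scatter), a number 0.72 log units higher from compound 1 to compound 3 (beyond the scatter) and a number 0.60 log units higher from compound 2 to compound 3 (beyond the scatter); only the two steps in which chloro replaces hydrogen on an aromatic carbon move the read-out beyond the scatter.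

Compound 4 `O=C(NNc1ccnc2cc(Cl)ccc12)c1ccccc1/N=C/c1cccs1` is not yet measured in this assay. It differs from compound 1 in one place: thiophen-2-yl in place of 2-chlorophenyl on a carbon with a double bond to nitrogen. Going by the values given here, no measured step exchanges one ring for another, so the only guide is indirect. The change removes a chlorine on the ring attached to the carbon with a double bond to nitrogen, and the measured steps show that adding a chlorine raised the read-out, as from compound 1 to compound 3 a number 0.72 log units higher from compound 1 to compound 3 (beyond the scatter). A drop beyond the scatter is therefore expected, of the order of a number 0.90 log units lower from compound 1 to compound 4 (beyond the scatter). Compound 4 is estimated at 4.6 in this assay, within a range from 4.1 to 5.1.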

Compound 4, partition coefficient: 4.78
Compound 4: the middle estimate sits 0.18 log units below what was measured; measured number inside the range.
By their numbers in this assay, from the lowest: compound 4; then compounds 1 and 2 (each within the scatter of the next); then compound 3.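

Until now, this place on a carbon with a double bond to nitrogen held only chlorinated phenyl rings, and exchanging the ring itself for thiophen-2-yl gives a number 0.72 log units lower from compound 1 to compound 4 (beyond the scatter) and a number 0.84 log units lower from compound 2 to compound 4 (beyond the scatter) in this assay. Against the dichlorinated ring the same exchange gives a number 1.44 log units lower from compound 3 to compound 4 (beyond the scatter) and is large. Compound 4 therefore stands lowest of the four compounds, with its steps to all three others beyond the scatter.

The compounds shown leave open where unsubstituted phenyl, or a phenyl ring carrying an amine or a carboxylic acid, would stand beside thiophen-2-yl, so the share of the chlorine and the share of the ring in these steps cannot be separated. No measurement at hand accounts for the size of these steps.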